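Norleucine to Methionine Side Chain in a Cyclic Peptide Series

The compounds below may be only part of what the source reports. "The series", "measured", "known", "first", "only" and "open" are said of these compounds alone.

The account concerns a cyclic peptide core carrying a variable side chain. Compound 1 `COc1ccc(C[C@H]2C(=O)N[C@@H](C)C(=O)N(C)[C@H]3Cc4ccc(cc4)Oc4cc(ccc4OC)C[C@@H](C(=O)N[C@H](C)C(=O)N[C@@H](CCC(=O)O)C(=O)N2C)N(C)C3=O)cc1` gives 219 nM in a functional assay on P388 cells (Mus musculus) for cytotoxicity; on this read-out higher numbers stand for weaker inhibition and lower numbers for stronger inhibition. Compound 2 `COc1ccc(C[C@H]2C(=O)N[C@@H](C)C(=O)N(C)[C@H]3Cc4ccc(cc4)Oc4cc(ccc4OC)C[C@@H](C(=O)N[C@H](C)C(=O)N[C@@H](CO)C(=O)N2C)N(C)C3=O)cc1` gives 14.1 nM, and compound 3 `CCC[C@@H]1NC(=O)[C@@H](C)NC(=O)[C@@H]2Cc3ccc(OC)c(c3)Oc3ccc(cc3)C[C@@H](C(=O)N2C)N(C)C(=O)[C@H](C)NC(=O)[C@H](Cc2ccc(OC)cc2)N(C)C1=O` gives 13.8 nM. Compound 3 has the lowest number of the three, but its gap to compound 2 is small: a 1.0-fold lower number from compound 2 to compound 3 (0.01 log units; within the scatter). Against compound 1 the gap is large, a 16-fold lower number from compound 1 to compound 3 (1.20 log units; beyond the scatter), as is a 16-fold lower number from compound 1 to compound 2 (1.19 log units; beyond the scatter).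

Compound 4 `COc1ccc(C[C@H]2C(=O)N[C@@H](C)C(=O)N(C)[C@H]3Cc4ccc(cc4)Oc4cc(ccc4OC)C[C@@H](C(=O)N[C@H](C)C(=O)N[C@@H](CCSC)C(=O)N2C)N(C)C3=O)cc1` has not been measured. It differs from compound 3 in this way: methylsulfanyl in place of methyl on a saturated chain carbon, two bonds along the chain from a saturated ring carbon. Among the compounds with values here, no measured step bears directly on methyl against methylsulfanyl. The steps that come closest show that removing the carboxy group from that chain made a large difference, while exchanging ethyl for hydroxy on the nearer chain carbon left the number within the scatter. A neutral side chain of similar length is therefore expected to behave like compound 3, with a 1.1-fold higher number from compound 3 to compound 4 (0.04 log units; within the scatter) expected to be within the scatter. Compound 4 is estimated at 15 nM, within 5 nM to 45 nM.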

Compound 4, half-maximal inhibitory concentration: 20.4 nM
Compound 4: middle estimate off by 1.4-fold (0.13 log units), on the low side, and the stated range covers the measured number.
By their numbers in this assay, from the lowest: compounds 3, 2 and 4 (each within the scatter of the next); then compound 1.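

In this assay, methylsulfanyl in place of methyl on a saturated chain carbon, two bonds along the chain from a saturated ring carbon, stays within the scatter (a 1.5-fold higher number from compound 3 to compound 4 (0.17 log units; within the scatter)), and (methylsulfanyl)methyl in place of hydroxy does the same (a 1.4-fold higher number from compound 2 to compound 4 (0.16 log units; within the scatter)). Methylsulfanyl in place of carboxy remains a large step (an 11-fold lower number from compound 1 to compound 4 (1.03 log units; beyond the scatter)), so a sulfur-bearing side chain joins the methyl and hydroxy compounds, and among these four only the carboxy compound stands apart. Nothing at hand gives a reason for this pattern.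

The compounds shown leave open whether an amine or a primary amide on this chain would read like compound 3 or like compound 1. They also leave open whether a chain longer than 2-(methylsulfanyl)ethyl would stay in the same range.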